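From 2-methoxyphenyl to 3-chlorophenyl on the amide-type nitrogen

The source may hold more compounds than are shown below. What is called first, only, known or untested is meant among the compounds shown, and "the series" means these compounds.

In a functional assay on MCF7 cells (Homo sapiens) for inhibition, read by MTT assay, with a stated time of 72 h (a higher number here means a weaker inhibitor, a lower number a stronger inhibitor), compound 3 (`COc1ccccc1NC(=O)C1CCN(C/C=C/c2ccccc2)CC1`) gives > 100000 nM as a limit and not as a number. Compound 1 (`CC(C)c1ccc(NC(=O)C2CCN(C/C=C/c3ccccc3)CC2)cc1`) reads 9100 nM on the same scale and compound 2 (`COc1cccc(NC(=O)C2CCN(C/C=C/c3ccccc3)CC2)c1`) reads 42700 nM on it too. Compound 3 therefore sits at the weak end of the three, and compound 1 at the strong end.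

Compound 4 (`O=C(Nc1cccc(Cl)c1)C1CCN(C/C=C/c2ccccc2)CC1`) has 3-chlorophenyl in place of 2-methoxyphenyl on an amide-type nitrogen. Within the data shown here, no chlorinated compound has been measured yet, so the evidence is indirect. The nearest measured change is an at least 2.3-fold higher number from compound 2 to compound 3 (0.36 log units; beyond the scatter) with 2-methoxyphenyl in place of 3-methoxyphenyl, an at least modest step that compound 4 may partly reverse. The steps from the 4-isopropylphenyl compound are wider: a 4.7-fold higher number from compound 1 to compound 2 (0.67 log units; beyond the scatter) is modest and an at least 10-fold higher number from compound 1 to compound 3 (1.04 log units; beyond the scatter) is large. They frame the spread of the series but do not point to compound 4 directly.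

A step of at least modest size towards a lower number is thus expected in this assay on the basis of compound 2 at 42700 nM as the closest reference. The expected size is an at least 3.3-fold lower number from compound 3 to compound 4 (0.52 log units; beyond the scatter) as an estimate. In this assay the estimate for compound 4 is 30000 nM with an expected range of 10000 nM to 90000 nM as a working figure.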

Compound 4, half-maximal inhibitory concentration: 16100 nM
Compound 4: middle estimate off by 1.9-fold (0.27 log units), on the high side; measured number inside the range.
By their numbers in this assay, from the lowest: compounds 1 and 4 (each within the scatter of the next); then compound 2. At a limit, above all of these: compound 3.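

In this assay, among these compounds, the swap with the ring position held constant gives a 2.7-fold lower number from compound 2 to compound 4 (0.42 log units; beyond the scatter), the first reading of chloro against methoxy without a change of place, and so the 3-substituted phenyl amide is sensitive to the identity of the group as well as to its position. Compound 4 also gives a 1.8-fold higher number from compound 1 to compound 4 (0.25 log units; within the scatter), so 3-chlorophenyl and 4-isopropylphenyl cannot be ordered here, and the level of compound 1 is no longer held by a single aryl group in the series. The full change gives an at least 6.2-fold lower number from compound 3 to compound 4 (0.79 log units; beyond the scatter), which is a bound and not a size, since one end of it is a limit: the limit of > 100000 nM in this assay, at which 1 of the 4 values shown sits.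

It remains open whether chloro keeps its edge over methoxy elsewhere on the ring, as 2-chlorophenyl and 4-chlorophenyl, which would separate the effect of the group from that of its place, are absent from the compounds shown. Also open, from the compounds shown here alone, is how far this level holds with an amine or a carboxylic acid on the phenyl ring, and whether any change to the rest of the shared core would alter these steps.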